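The compounds below may be only part of what the source reports. "The series", "measured", "known", "first", "only" and "open" are said of these compounds alone.

The measured compounds:

Compound 1, `CCCCCCCCC#Cc1cn(C/C=C/CN2C(=O)c3ccccc3C2=O)c(=O)[nH]c1=O`, in a functional assay on MCF7 cells (Homo sapiens) for antiproliferative activity, read by MTT assay, with a stated time of 3 days (a higher number here means a weaker inhibitor, a lower number a stronger inhibitor), gives 66000 nM.
Compound 2, `CCCCCc1ccc(C#Cc2cn(C/C=C\CN3C(=O)c4ccccc4C3=O)c(=O)[nH]c2=O)cc1`, gives in this assay a value that is a limit of the assay, > 100000 nM.
Compound 3, `CCCCCC#Cc1cn(C/C=C/CN2C(=O)c3ccccc3C2=O)c(=O)[nH]c1=O`, gives 44000 nM.

Among the two numbers that are not limits, compound 3 holds the lowest, but its nearest neighbour is compound 1, and the step of a 1.5-fold lower number from compound 1 to compound 3 (0.18 log units; within the scatter) is within the scatter, so the two compounds cannot be ordered against each other.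

Compound 4, `CCCCCc1ccc(C#Cc2cn(C/C=C/CN3C(=O)c4ccccc4C3=O)c(=O)[nH]c2=O)cc1`, differs from compound 3 in one place: 4-pentylphenyl in place of pentyl on a triple-bonded carbon. Among the compounds with values here, the only measured step, from compound 1 to compound 3, exchanges one saturated chain for a shorter one and stays within the scatter; it does not involve an aromatic ring and so bears only loosely on the present change. Compound 2, which also carries the 4-pentylphenyl group, reached only the limit (the limit of > 100000 nM in this assay, at which 1 of the 3 values shown sits). The direction of the step in this assay is therefore uncertain, and a loss of potency is at least as likely as a gain. Compound 4 is expected to give about 80000 nM, between 30000 nM and 200000 nM, which would mean an estimated step of a 1.8-fold higher number from compound 3 to compound 4 (0.26 log units; within the scatter).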

Compound 4, half-maximal inhibitory concentration: 5600 nM
For compound 4 the middle estimate is 14-fold (1.15 log units) above the measured one; the whole stated range lies above it.
By their numbers in this assay, from the lowest: compound 4; then compounds 3 and 1 (each within the scatter of the next). At a limit, above all of these: compound 2.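

In this assay, the triple-bonded carbon turns out to respond to the kind of group it carries: 4-pentylphenyl gives a 7.9-fold lower number from compound 3 to compound 4 (0.90 log units; beyond the scatter) and a 12-fold lower number from compound 1 to compound 4 (1.07 log units; beyond the scatter), whereas the exchange between the two saturated chains had stayed within the scatter. Compound 2 carries the same group but stands at a limit of the assay: the limit of > 100000 nM in this assay, at which 1 of the 4 values shown sits. The group alone therefore does not account for the result, as the step of an at least 17-fold lower number from compound 2 to compound 4 (1.25 log units; beyond the scatter) comes with the double bond alone, drawn Z in compound 2 and E in compound 4: the fact that compounds 2 and 4 differ only in the configuration as drawn.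

The compounds shown leave open whether the aromatic ring alone carries the change or its pentyl chain takes part, which a plain phenyl group would test. They also do not show how a hydroxyl group or an amine at the end of that chain would read.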